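The source may report more compounds than this note shows. Statements on the series, on what has been measured and on what is new or still open speak of the compounds shown alone.

Of the compounds shown here, three have been measured in a functional assay on MIA PaCa-2 cells (Homo sapiens) for inhibition, read by MTT assay, with a stated time of 72 h; on this read-out lower numbers stand for stronger inhibition of growth and higher numbers for weaker inhibition of growth. Compound 1 `COc1cccc(CNCCCNS(=O)(=O)c2cc(C(F)(F)F)cc(C(F)(F)F)c2)c1` gives 3400 nM, and compound 3 `COc1ccccc1CNCCCNS(=O)(=O)c1cc(C(F)(F)F)cc(C(F)(F)F)c1` gives 3100 nM. Going by the values given here, the only single-point step between them is a 1.1-fold lower number from compound 1 to compound 3 (0.04 log units; within the scatter). Compound 2 `O=S(=O)(NCCCCCCNCc1ccc(Br)cc1)c1ccccc1F` gives 13300 nM, the highest of the three numbers; its nearest neighbour on this scale is compound 1, and compound 3 lies furthest from it, both gaps beyond the scatter.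

Compound 4 `Cc1ccc(S(=O)(=O)NCCCCCCNCc2ccc(Br)cc2)cc1` differs from compound 2 in one place: 4-methylphenyl in place of 2-fluorophenyl on a sulfonyl sulfur. Among the compounds with values here, none of the measured steps touches the group on the sulfonyl sulfur; the single step seen, from compound 1 to compound 3, changes the group on the saturated chain carbon bound to an amine nitrogen and stays within the scatter, so it carries little information for this change. Within the data shown here, with no comparable precedent, no step beyond the scatter is expected in either direction, and the estimated 1.1-fold lower number from compound 2 to compound 4 (0.04 log units; within the scatter) reflects that. Compound 4 is therefore estimated at 12000 nM, with a range from 4000 nM to 40000 nM.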

Compound 4, concentration for 50% growth inhibition: 12300 nM
Beside the measured number, compound 4's estimate is 1.0-fold (0.01 log units) below it; the measured number falls inside the stated range.
By their numbers in this assay, from the lowest: compounds 3 and 1 (each within the scatter of the next); then compounds 4 and 2 (each within the scatter of the next).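

Going by these compounds alone, this is the first step to touch the group on the sulfonyl sulfur: in this assay, 4-methylphenyl in place of 2-fluorophenyl gives a 1.1-fold lower number from compound 2 to compound 4 (0.03 log units; within the scatter). The two groups match in heavy-atom count and both lack hydrogen-bond donors and acceptors, but they differ in which substituent the ring carries and where it sits, and this exchange still produces no difference beyond the scatter. No measurement here bears on why these two groups give such similar numbers.

As far as these compounds go, it remains open whether a group of a different kind on the sulfonyl sulfur, such as a pyridine ring or a phenyl ring carrying a carboxylic acid or an amine, would shift the number beyond the scatter. Compounds 2 and 4 differ from compounds 1 and 3 in more than one place, so the gap between the two pairs cannot be assigned to any single feature.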